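A few compounds are considered here, and "the series" means these few. Any claim that something is new, unique, unknown or untested is made for them only; others in the source may bear on it.

Compound 1 `COc1ccc(C2=C(c3cc(OC)c(OC)c(OC)c3)C(=O)CC2O[SiH2]C(C)(C)C)cc1`: > 100 ug/mL
Compound 2 `COc1ccc(OC)c(C2=C(c3cc(OC)c(OC)c(OC)c3)C(=O)CC2O[SiH2]C(C)(C)C)c1`: 19 ug/mL
Compound 3 `COc1ccc(C2=C(c3cc(OC)c(OC)c(OC)c3)C(=O)CC2O)cc1`: > 100 ug/mL

All three were tested in an ADME assay on HEp-2 cells (Homo sapiens) for cytotoxicity, read by MTT assay, with a stated time of 72 h; a lower number here means a stronger inhibitor, a higher number a weaker inhibitor. Compound 1 gives only a limit of the assay, not a number. Compound 3 likewise gives only a limit. Both sit at the limit of > 100 ug/mL in this assay, at which 2 of the 3 values shown sit. For the measured compounds named here, compound 2 is the one compound with a true number.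

Compound 1 and compound 2 differ by 2,5-dimethoxyphenyl in place of 4-methoxyphenyl on a double-bonded ring carbon, and this gives an at least 5.2-fold lower number from compound 1 to compound 2 (0.72 log units; beyond the scatter). Compound 1 and compound 3 differ by a hydrogen atom in place of a group of 5 heavy atoms (4 carbon, 1 silicon; no ring), on an oxygen on a saturated carbon, which gives a step that the two limits leave unreadable from compound 1 to compound 3.

Compound 4 `COc1ccc(OC)c(C2=C(c3cc(OC)c(OC)c(OC)c3)C(=O)CC2O)c1` has not yet been measured. It differs from compound 2 by a hydrogen atom in place of a group of 5 heavy atoms (4 carbon, 1 silicon; no ring), on an oxygen on a saturated carbon, the same change as from compound 1 to compound 3, at the same place. The step from compound 2 to compound 4 in this assay is expected to be small, a 1.6-fold higher number from compound 2 to compound 4 (0.20 log units; within the scatter), but with wide uncertainty, since the earlier step of this kind, a step that the two limits leave unreadable from compound 1 to compound 3, has no readable size. Compound 4 is therefore estimated at 30 ug/mL, somewhere between 10 ug/mL and 100 ug/mL.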

Compound 4, half-maximal inhibitory concentration: > 100 ug/mL
Compound 4 was reported as a limit (the forecaster's own chance of this, stated with the estimate: 35%); at least 3.3-fold (0.52 log units) between middle value and limit.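

On the core of compound 2, putting a hydrogen atom in place of the silicon-bearing group of 5 heavy atoms, on the oxygen, gives an at least 5.2-fold higher number from compound 2 to compound 4 (0.72 log units; beyond the scatter). The same change cannot be read on the core of compound 1, where both ends of the step are limits of the assay, so nothing shows that the change has the same size on both cores. Compound 4 also gives only a limit, so the new step sets a minimum and not a true size: the limit of > 100 ug/mL in this assay, at which 3 of the 4 values shown sit.

The compounds shown leave open whether the silicon itself matters. A benzyl or acetyl group on that oxygen would test whether other groups give a number like that of compound 2.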